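Working notes: 3-chloro-4-fluorophenyl replacing 4-methoxyphenyl

The source may hold more compounds than are shown below. What is called first, only, known or untested is meant among the compounds shown, and "the series" means these compounds.

Measured in an ADME assay on the whole organism (Rattus norvegicus, strain Sprague-Dawley) for pharmacokinetics, using cassette dosing, at a dose of 0.5 mg/kg by the intravenous route; on this read-out higher numbers stand for fast clearance and lower numbers for slow clearance:
- compound 1 `O=C(Nc1ccc2[nH]c(=O)oc2c1)C(=O)N1CCN(c2ccc(C(F)(F)F)cc2)CC1`: 15.1 mL/min/kg
- compound 2 `COc1ccc(N2CCN(C(=O)C(=O)Nc3ccc4[nH]c(=O)oc4c3)CC2)cc1`: "not determined" (no result reported)

Compound 2 has no number on this read-out, so it gives no starting value. Compound 3 `O=C(Nc1ccc2[nH]c(=O)oc2c1)C(=O)N1CCN(c2ccc(F)c(Cl)c2)CC1` differs from it as follows: 3-chloro-4-fluorophenyl in place of 4-methoxyphenyl on an amine nitrogen in a ring. Within the data shown here, no measured step covers this change in this assay, so no direction can be assigned. Among the measured compounds shown here, the only available number is that of compound 1 at 15.1 mL/min/kg, and a step beyond the scatter from that value is not expected. Compound 3 is expected at 15 mL/min/kg, with an estimated range of 7 mL/min/kg to 32 mL/min/kg.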

Compound 3, clearance: 18.3 mL/min/kg
The estimate for compound 3 lay 1.2-fold (0.09 log units) below the measured number, within the range that was stated.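

In this assay, among these compounds, 3-chloro-4-fluorophenyl in place of 4-(trifluoromethyl)phenyl on the amine nitrogen in the ring gives a 1.2-fold higher number from compound 1 to compound 3 (0.08 log units; within the scatter) and is the first step that can be read at this position. On this read-out the two substituted phenyl groups stand within the scatter of each other, so the position tolerates this change without a clear shift in clearance. Nothing at hand accounts for this result. Still open, as far as these compounds go, is how a pyridyl or benzyl group on the same nitrogen would read in this assay.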